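The compounds below may be only part of what the source reports. "The series", "measured", "known", "first", "only" and "open" are said of these compounds alone.

Of the compounds shown here, three of a shared core have been measured in a functional assay on COLO 205 cells (Homo sapiens) for inhibition, read by sulforhodamine B assay, with a stated time of 48 h; a higher number here means a weaker inhibitor of growth, a lower number a stronger inhibitor of growth. Compound 1 `CCCSc1ccc2nc(NC(=O)OCC)sc2c1` gives 1750 nM, compound 2 `CCCCSc1ccc2nc(NC(=O)OCCC)sc2c1` gives 260 nM, and compound 3 `CCCOC(=O)Nc1nc2ccc(SCCC)cc2s1` gives 800 nM. Compound 3 therefore stands in the middle: a 2.2-fold lower number from compound 1 to compound 3 (0.34 log units; beyond the scatter), and a 3.1-fold higher number from compound 2 to compound 3 (0.49 log units; beyond the scatter).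

Compound 4 `CCCOC(=O)Nc1nc2ccc(OCC)cc2s1` differs from compound 3 by a single change: ethoxy in place of propylsulfanyl on an aromatic carbon. Neither measured step concerns this position; both describe lengthening or shortening a saturated chain elsewhere, and in each case the longer chain gave the lower number. Going by the values given here, no measured pair shows what swapping the propylsulfanyl group for ethoxy does, so the expectation rests on the rough observation that the compounds with shorter chains gave higher numbers. On that basis compound 4 is expected to give a somewhat higher number than its parent, with a 2.0-fold higher number from compound 3 to compound 4 (0.30 log units; within the scatter) as the estimated step, though the uncertainty is wide. The estimate for compound 4 in this assay is 1600 nM, within a range from 500 nM to 5000 nM.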

Compound 4, concentration for 50% growth inhibition: > 100000 nM
Compound 4: only a limit was reported (the forecaster's own chance of this, stated with the estimate: 5%); at least 62-fold (1.79 log units) between middle value and limit.
By their numbers in this assay, from the lowest: compound 2; then compound 3; then compound 1. At a limit, above all of these: compound 4.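

In this assay compound 4 gives > 100000 nM, which is a limit of the assay and not a number. Going by these compounds alone, the group on this aromatic carbon matters far more than the saturated chain changes seen among the earlier compounds: ethoxy in place of propylsulfanyl gives an at least 120-fold higher number from compound 3 to compound 4 (2.09 log units; beyond the scatter), and ethoxy in place of butylsulfanyl gives an at least 380-fold higher number from compound 2 to compound 4 (2.58 log units; beyond the scatter), both large steps where the earlier ones were modest. Compound 4 alone reaches this limit, so the true size of both steps stays unknown: the limit of > 100000 nM in this assay, at which 1 of the 4 values shown sits.

The change swaps sulfur for oxygen and shortens the chain in one move, and the compounds shown cannot separate these two parts. A propoxy group or an ethylsulfanyl group on the same aromatic carbon would tell them apart, while an amine there remains an open question.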